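The compounds below may be only part of what the source reports. "The series", "measured", "known", "first", "only" and "open" are said of these compounds alone.

Among the measured compounds, compound 3 `N#Cc1cc(F)cc(C(=O)Nc2cccc(Cl)c2)c1` stands lowest: in an in vitro functional assay on HEK293-A cells for antagonist activity at metabotropic glutamate receptor 5 (Rattus norvegicus), read by calcium flux (on this read-out higher numbers stand for weaker inhibition and lower numbers for stronger inhibition), compound 3 gives 45 nM. Its nearest neighbour, compound 2 `N#Cc1cc(F)cc(C(=O)Nc2cccc(F)c2)c1`, gives 2160 nM in this assay, and the step of a 48-fold lower number from compound 2 to compound 3 (1.68 log units; beyond the scatter) is large. Compound 1 `N#Cc1cc(F)cc(C(=O)Nc2ccccc2F)c1` gives > 30000 nM in this assay, which is a limit of the assay rather than a number (the limit of > 30000 nM in this assay, at which 1 of the 3 values shown sits). Compound 4 `N#Cc1cc(F)cc(C(=O)Nc2cccc(Cl)c2F)c1` differs from compound 3 by fluoro in place of hydrogen on an aromatic carbon. Going by the values given here, no measured step tests this particular change; the single measured step concerns the exchange of fluoro for chloro, a different alteration. The expectation is therefore a step within the scatter, a 1.3-fold higher number from compound 3 to compound 4 (0.12 log units; within the scatter). Compound 4 is estimated at 60 nM, with a range from 15 nM to 250 nM.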

Compound 4, half-maximal inhibitory concentration: 347 nM
Beside the measured number, compound 4's estimate is 5.8-fold (0.76 log units) below it; the measured number lies above the stated range.
By their numbers in this assay, from the lowest: compound 3; then compound 4; then compound 2. At a limit, above all of these: compound 1.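

In this assay, fluoro at this position, ortho to a chloro group, weakens inhibition: a 7.7-fold higher number from compound 3 to compound 4 (0.89 log units; beyond the scatter). Compound 4 shows that this fluoro does not abolish activity when chloro is present, with an at least 86-fold lower number from compound 1 to compound 4 (1.93 log units; beyond the scatter) as the step that adds the chloro. The value of compound 1 is a limit of the assay and not a number: the limit of > 30000 nM in this assay, at which 1 of the 4 values shown sits.

Going by these compounds, whether a methyl or methoxy group at this position would weaken inhibition as fluoro does remains open. So does the effect of an amine there.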